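The compounds below may be only part of what the source reports. "The series", "measured", "known", "first", "only" and "open" are said of these compounds alone.

Compound 1 `COc1ccccc1/C=C/C(=O)c1ccc(OCC(=O)N[C@H]2CCOC2=O)cc1` is the starting point of this account. In a functional assay on MCF7 cells (Homo sapiens) for antiproliferative activity, read by MTT assay, with a stated time of 72 h (a lower number here means a stronger inhibitor, a higher number a weaker inhibitor), compound 1 gives only a limit of the assay, > 64000 nM. Compound 2 `CCOc1ccccc1OCCSC(=S)N[C@H]1CCOC1=O` belongs to the same small set. In this assay compound 2 likewise gives only a limit, > 64000 nM. Both measured values thus share the same boundary: the limit of > 64000 nM in this assay, at which 2 of the 2 values shown sit. Compound 1 is therefore not resolved as a number within the tested range. Compound 3 `O=C(COc1ccc(C(=O)/C=C/c2ccccc2Br)cc1)N[C@H]1CCOC1=O` has not yet been measured. It differs from compound 1 in one place: bromo in place of methoxy on an aromatic carbon. Going by the values given here, no step between measured compounds is available, so no direction for this change can be read from the data. On the basis of two compounds at the limit, the expected step that the limit leaves unreadable from compound 1 to compound 3 is no movement beyond the scatter. Compound 3 is accordingly expected to give about 80000 nM, in a range from 20000 nM to 300000 nM, most likely again as a limit.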

Compound 3, half-maximal inhibitory concentration: 15300 nM
The estimate for compound 3 lay 5.2-fold (0.72 log units) above the measured number; the measured number lies below the stated range.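

At this position, ortho to a large group, the change of 2-methoxyphenyl to 2-bromophenyl gives in this assay an at least 4.1-fold lower number from compound 1 to compound 3 (0.62 log units; beyond the scatter), so the aromatic carbon in question is one at which a single exchange can bring a compound of this set into the measurable range. Compound 1 remains a limit, so the step gives only a minimum size and the full effect of the exchange cannot be read. Compound 3 is the only compound shown with a number, while the other two stay at the boundary: the limit of > 64000 nM in this assay, at which 2 of the 3 values shown sit.

The compounds shown do not tell why bromo differs from methoxy here, nor whether chloro or an amine on the same aromatic carbon would also leave the limit. Going by these compounds, how bromo would behave on another carbon of this ring also remains open.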